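Pyrazolyl ureas with benzyloxybenzyl diazepane or piperazine cores

A few compounds are considered here, and "the series" means these few. Any claim that something is new, unique, unknown or untested is made for them only; others in the source may bear on it.

Measured compounds:
- compound 1 `O=C(N1CCCN(Cc2ccc(OCc3ccccc3)cc2)CC1)n1cccn1`: in an assay on membranes from brain for binding affinity to neutral cholesterol ester hydrolase 1 (Mus musculus), read by fluorescence, with stated times of 1 h and 30 min (a higher number here means a weaker inhibitor, a lower number a stronger inhibitor), compound 1 gives > 100000 nM, a limit of the assay.
- compound 2 `N#Cc1cnn(C(=O)N2CCCN(Cc3ccc(OCc4ccccc4)cc3)CC2)c1`: in this assay compound 2 gives > 100000 nM, a limit of the assay.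
- compound 3 `O=C(N1CCN(C(c2ccc(OCc3ccccc3)cc2)c2ccc(OCc3ccccc3)cc2)CC1)n1cccn1`: in this assay compound 3 gives > 100000 nM, a limit of the assay.

Compounds 1 and 2 share one core and differ only by cyano in place of hydrogen on an aromatic carbon. Among the measured compounds shown here, the step that the two limits leave unreadable from compound 1 to compound 2 cannot be read, since both values are limits; the only evidence bearing on it is the limit of > 100000 nM in this assay, at which 3 of the 3 values shown sit. The difference between the core of compound 1 and the core of compound 3 is not broken down here.

Compound 4 `N#Cc1cnn(C(=O)N2CCN(C(c3ccc(OCc4ccccc4)cc3)c3ccc(OCc4ccccc4)cc3)CC2)c1` is not yet measured. It differs from compound 3 by cyano in place of hydrogen on an aromatic carbon, the same change as from compound 1 to compound 2, made at the same place on the same five-membered aromatic ring with 2 nitrogen. Given that the same change on the core of compound 1 left both values at the limit, and that compound 3 itself sits at the limit, the expected step that the limit leaves unreadable from compound 3 to compound 4 is no more than a placeholder, and the most likely outcome for compound 4 is again a limit rather than a number. For compound 4 the estimate in this assay is 200000 nM, with an expected range from 100000 nM to 1000000 nM.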

Compound 4, half-maximal inhibitory concentration: > 100000 nM
Compound 4: a limit, no number; the forecaster's own chance of this, stated with the estimate: 90%; the middle value is on the limit's open side.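

Compound 3 and compound 4 both sit at a limit of this assay rather than at a number, so the step from hydrogen to cyano on this core cannot be read: the limit of > 100000 nM in this assay, at which 4 of the 4 values shown sit.

The compounds shown leave open whether any member of the series gives a number in this assay, and what size the change from 1H-pyrazol-1-yl to 4-cyano-1H-pyrazol-1-yl has on either core.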